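A Fourth Methoxy Group on a Chalcone Core

A few compounds are considered here, and "the series" means these few. Any claim that something is new, unique, unknown or untested is made for them only; others in the source may bear on it.

Compound 1, `COc1ccc(C(=O)/C=C/c2cccc(OC)c2OC)c(O)c1`: 69.7%
Compound 2, `COc1cc(C(=O)CCc2cccc(OC)c2OC)ccc1O`: 91.1%
Compound 3, `COc1ccc(C(=O)/C=C/c2cc(OC)ccc2OC)c(O)c1`: 71.1%

Of the compounds shown here, three have so far been tested in an ADME assay on RAW264.7 cells (Mus musculus) for cytotoxicity, read by MTT assay, with a stated time of 24 h, tested at 5 ug/mL; on this read-out higher numbers stand for a weaker effect at the one concentration tested and lower numbers for a stronger effect. Compound 1 shows the lowest number of the three, but compound 3 sits within the usual scatter of it, so the two cannot be told apart on this read-out. Compound 2, which carries a saturated link in place of the double bond, stands clearly higher, beyond the scatter, and so shows the weaker effect at the single concentration tested.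

The next compound, compound 4, `COc1ccc(C(=O)/C=C/c2ccc(OC)c(OC)c2OC)c(O)c1`, comes from compound 1 by one change: methoxy in place of hydrogen on an aromatic carbon. For the measured compounds named here, no pair of measured compounds differs by a single such change, so there is no measured step to lean on. The comparison of compound 1 with compound 3, which both carry the double bond and differ only in where their methoxy groups sit, suggests that moving or adding a methoxy group leaves the number close to where it was. The step from compound 1 to compound 4 is therefore expected to be small, a number 2.3 percentage points higher from compound 1 to compound 4 (within the scatter), not beyond the scatter. For compound 4 in this assay the estimate is 72%, with a range from 58% to 86%.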

Compound 4, a percentage reported as activity, at one concentration (the size of the read-out at that concentration, not a potency): 72.5%
Estimate against measurement, compound 4: 0.5 percentage points below; the range from low to high includes it.
By their numbers in this assay, from the lowest: compounds 1, 3 and 4 (each within the scatter of the next); then compound 2.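

For the compounds shown here, compound 4 provides the first step in this set that isolates a single change: in this assay, methoxy in place of hydrogen on an aromatic carbon, ortho to a methoxy group, meta to a methoxy group and para to a large group, gives a number 2.8 percentage points higher from compound 1 to compound 4 (within the scatter) and so stays inside the usual variation between repeated measurements. Going by these compounds alone, at this position, and at the single concentration tested, adding the methoxy group therefore produces no change that can be told apart from that variation, which the earlier compounds could not show since no two of them differed in only one place. Nothing available here gives a measured reason for this outcome.

Still open, on these data alone, is whether other groups on this same carbon, such as an amine, a carboxylic acid or a longer chain like ethoxy, would also leave the number in place. The compounds shown also leave open whether this single result holds for a methoxy group added at another carbon of the ring, or for the same change on a core with a saturated link.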